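Notes on a chloro to methyl step

A few compounds are considered here, and "the series" means these few. Any claim that something is new, unique, unknown or untested is made for them only; others in the source may bear on it.

In a functional assay on NCI-H460 cells (Homo sapiens) for inhibition, read by MTT assay, with a stated time of 24 h, tested at 100 ug/mL (on this read-out higher numbers stand for more inhibition of growth at the one concentration tested and lower numbers for less inhibition of growth), compound 1 `O=C(CCCCC1CCSS1)Nc1ccccc1Cl` gives 3.38% and compound 2 `O=C(CCCCC1CCSS1)Nc1cccc(C(F)(F)F)c1` gives 68.8% at the single concentration tested. Compound 3 `O=C(CCCCC(S)CCS)Nc1cccc(Cl)c1` gives 24.8% and stands second highest of the three, above compound 1 and below compound 2, with both gaps beyond the scatter.

The next compound is compound 4 `Cc1cccc(NC(=O)CCCCC(S)CCS)c1` and it differs from compound 3 in one place: methyl in place of chloro on an aromatic carbon. Among the compounds with values here, no measured pair differs in one place only, so the data give no direct guide to the size of this step, and the wide spread among the three values argues for a broad range. The expectation in this assay is a slight fall at most, nothing beyond the scatter. The estimated change a number 2.8 percentage points lower from compound 3 to compound 4 (within the scatter) is expected to stay small. In this assay compound 4 is estimated at 22% with an expected range from 8% to 42% for now.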

Compound 4, percent growth inhibition at one concentration: 23.1%
For compound 4 the middle estimate is 1.1 percentage points below the measured one; the range from low to high includes it.
By their numbers in this assay, from the lowest: compound 1; then compounds 4 and 3 (each within the scatter of the next); then compound 2.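

In this assay, within the data shown here, the first comparison that differs in one place only reads a number 1.7 percentage points lower from compound 3 to compound 4 (within the scatter), so the two compounds cannot be told apart on this read-out. At this place, on an aromatic carbon meta to a large group, methyl in place of chloro is tolerated on the shared core, and the series now has one measured size for a step of this kind, though only for this single pair. Nothing on hand explains why the exchange leaves the two compounds indistinguishable.

Open, going by these compounds, is whether a larger or differently built group at the same place, such as a nitrile, an amine or a carboxylic acid, would also read like chloro and methyl. Also open, on these data alone, is whether the same exchange on the core of compound 2 would give an equally small step.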